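The source may hold more compounds than are shown below. What is called first, only, known or untested is meant among the compounds shown, and "the series" means these compounds.

The study starts from two measured compounds that share a core. Compound 1, `COC1(/C=C/COCc2ccc3c(ccc(=O)n3C)c2)CCOCC1`, carries a methoxy on a saturated ring carbon and an allylic ether linker. Compound 2, `CO/C(=C\C(=O)OCc1ccc2c(ccc(=O)n2C)c1)C1(OC)CCOCC1`, instead carries an unsaturated ester linker with a second methoxy on its double-bonded chain carbon. In a functional assay for inhibition, with Homo sapiens as the target (on this read-out higher numbers stand for weaker inhibition and lower numbers for stronger inhibition), compound 1 gives 500 nM. In this assay compound 2 gives 2600 nM, the highest of the two numbers seen so far; the gap to compound 1 lies beyond the usual scatter, so compound 2 is the weaker inhibitor of the pair.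

The next compound, compound 3, `COC1(/C(C)=C/C(=O)OCc2ccc3c(ccc(=O)n3C)c2)CCOCC1`, is not yet measured. It differs from compound 2 in one place: methyl in place of methoxy on a double-bonded chain carbon bound to a double-bonded chain carbon and a saturated ring carbon. Among the compounds with values here, no pair of measured compounds isolates this change, so its effect in this assay cannot be read from the data at hand. The expectation is a modest step, if any, toward a lower number, of a size that may not clearly exceed the scatter; that expected step is a 1.7-fold lower number from compound 2 to compound 3 (0.24 log units; within the scatter). Compound 3 is accordingly estimated at 1500 nM, within a range from 450 nM to 5000 nM.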

Compound 3, half-maximal inhibitory concentration: 2100 nM
The estimate for compound 3 lay 1.4-fold (0.15 log units) below the measured number, within the range that was stated.
By their numbers in this assay, from the lowest: compound 1; then compounds 3 and 2 (each within the scatter of the next).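

In this assay, methyl in place of methoxy on a double-bonded chain carbon bound to a double-bonded chain carbon and a saturated ring carbon gives a 1.2-fold lower number from compound 2 to compound 3 (0.09 log units; within the scatter), so the two groups cannot be told apart at this position. This is the only pair shown that differs in one place, and it adds what the earlier comparison could not isolate: with the rest of the structure held constant, exchanging a methoxy, with two heavy atoms and one hydrogen-bond acceptor, for a methyl, with one heavy atom and no hydrogen-bond acceptor, leaves the read-out within the scatter. Nothing measured here offers an explanation for this result.

The compounds shown leave open whether a group of another kind on this carbon, such as an amine or a carboxylic acid, would shift the number beyond the scatter. They also leave open whether an ethyl group there would read like the methyl, and whether the exchange of methoxy for methyl would read the same way with a different linker.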